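Squaric-free note on a tert-butyl grown by one carbon

The source may hold more compounds than are shown below. What is called first, only, known or untested is meant among the compounds shown, and "the series" means these compounds.

Compound 1, `Cc1ccc(C/N=c2\c(O)c(O)\c2=N/C(C)(C)C)c(C)c1`, gives 630 nM in a functional assay for inhibition, with Rattus norvegicus as the target; a lower number here means a stronger inhibitor, a higher number a weaker inhibitor.
Compound 2, `CCc1cc(C#N)ccc1Nc1c(N[C@H](C)C(C)(C)C)c(=O)c1=O`, gives 90 nM in this assay.
Compound 3, `CC(C)(C)/N=c1\c(O)c(O)\c1=N/Cc1ccc(Cl)cc1`, gives 1700 nM in this assay.

Among the three measured compounds, compound 1 stands second highest. Its nearest neighbour is compound 3, whose number is higher by a gap beyond the scatter; the furthest is compound 2, whose number is lower, again beyond the scatter. No pair of these compounds differs in a single place, so no measured step is available to guide the next one.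

Compound 4, `CCC(C)(C)/N=c1\c(O)c(O)\c1=N/Cc1ccc(C)cc1C`, differs from compound 1 in one place: methyl in place of hydrogen on a saturated chain carbon, two bonds along the chain from a double-bonded nitrogen. Seen one bond further out, this is tert-butyl becoming 1,1-dimethylpropyl. For the measured compounds named here, nothing among the measured compounds shows the effect of lengthening this chain, so the step is expected to be small, in either direction, and most likely within the scatter. The step of a 1.1-fold lower number from compound 1 to compound 4 (0.06 log units; within the scatter) is the expected size. Compound 4 is therefore estimated at 550 nM, within a range of 200 nM to 1500 nM.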

Compound 4, half-maximal inhibitory concentration: 530 nM
Compound 4: middle estimate off by 1.0-fold (0.02 log units), on the high side; the measured number falls inside the stated range.
By their numbers in this assay, from the lowest: compound 2; then compounds 4 and 1 (each within the scatter of the next); then compound 3.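

Tert-butyl grown to 1,1-dimethylpropyl gives the only measured step at this position, and in this assay it reads a 1.2-fold lower number from compound 1 to compound 4 (0.08 log units; within the scatter) and so cannot be told apart from repeat measurement. For the compounds shown here, on the core of compound 1, this saturated chain carbon therefore carries a methyl in place of hydrogen with no measurable consequence, something the earlier compounds could not show. Nothing available explains this result.

The compounds shown leave open whether a longer chain, such as n-butyl, or a ring, such as cyclohexyl, would be accommodated at this place in the same way, or whether a hydroxyl or an amine on the chain would be. They also leave open whether the same methyl gives a step of similar size on the core of compound 3.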